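Replacing a Hydroxyazetidine with Aryl Rings: Solubility

The source may report more compounds than this note shows. Statements on the series, on what has been measured and on what is new or still open speak of the compounds shown alone.

Compound 1 `OC1CN(c2nccnc2OC2CN(c3ccc4ccccc4n3)C2)C1` gives 41000 nM in a physicochemical assay for solubility, in phosphate buffer, at pH 7.4; on this read-out lower numbers stand for lower solubility and higher numbers for higher solubility.
Compound 2 `N#Cc1ccc(-c2nccnc2OC2CN(c3ccc4ccccc4n3)C2)cc1` gives < 1000 nM, which is a limit of this assay rather than a number.
Compound 3 `c1ccc2nc(N3CC(Oc4nccnc4-c4cncnc4)C3)ccc2c1` gives 254000 nM.

Compound 1 holds the lower of the two numbers given; the step to its nearest measured neighbour is a 6.2-fold higher number from compound 1 to compound 3 (0.79 log units; beyond the scatter). The other measured step from it is an at least 41-fold lower number from compound 1 to compound 2 (1.61 log units; beyond the scatter), where the value sits at the limit of < 1000 nM in this assay, at which 1 of the 3 values shown sits.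

Compound 4 `Cc1ncccc1-c1nccnc1OC1CN(c2ccc3ccccc3n2)C1` is not yet measured. It differs from compound 1 in one place: 2-methylpyridin-3-yl in place of 3-hydroxyazetidin-1-yl on an aromatic carbon. Both measured steps from compound 1 bear on it, since each also exchanges the same azetidine for a six-membered aromatic ring, yet they point in opposite directions: a large fall with the 4-cyanophenyl, a modest rise with the pyrimidin-5-yl. A 2-methylpyridin-3-yl sits between those two rings in make-up, carrying one ring nitrogen and a methyl. Compound 4 is therefore expected to land below compound 1, with a step of a 2.7-fold lower number from compound 1 to compound 4 (0.44 log units; beyond the scatter), and its estimated solubility is 15000 nM, within a range of 2000 nM to 100000 nM.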

Compound 4, solubility: 253000 nM
Compound 4: middle estimate off by 17-fold (1.23 log units), on the low side; measured number outside the range, above it.
By their numbers in this assay, from the lowest: compound 1; then compounds 4 and 3 (each within the scatter of the next). At a limit, below all of these: compound 2.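

In this assay, a 6.2-fold higher number from compound 1 to compound 4 (0.79 log units; beyond the scatter) shows that the rise over 3-hydroxyazetidin-1-yl at this position, on an aromatic carbon next to the ring nitrogen, is not confined to pyrimidin-5-yl. Between the two replacing rings, a 1.0-fold lower number from compound 3 to compound 4 (0.00 log units; within the scatter), so they cannot be told apart here, while 4-cyanophenyl alone goes against the rise, with an at least 250-fold higher number from compound 2 to compound 4 (2.40 log units; beyond the scatter). The value of compound 2 is a limit of the assay and not a number: the limit of < 1000 nM in this assay, at which 1 of the 4 values shown sits.

The compounds shown leave open what the methyl and the ring nitrogen of 2-methylpyridin-3-yl each contribute to this number. They also leave open how an unsubstituted phenyl ring or an open-chain amine such as dimethylamino would stand at this position.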